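Dropping one methoxy group: what the cells show

The source may report more compounds than this note shows. Statements on the series, on what has been measured and on what is new or still open speak of the compounds shown alone.

Measured so far:
compound 1 `COc1cc(-c2cc(/C=C/C(=O)c3ccc(N)cc3)[nH]n2)cc(OC)c1OC` gives 62%
compound 2 `COc1ccc(-c2cc(/C=C/C(=O)c3ccc(N)cc3)[nH]n2)cc1OC` gives 69%
compound 3 `COc1cc(C(=O)/C=C/c2cc(-c3cc(OC)c(OC)c(OC)c3)n[nH]2)cc(OC)c1OC` gives 79%

All three were tested in a functional assay on OVCAR-4 cells (Homo sapiens) for cytotoxicity, read by sulforhodamine B assay, with a stated time of 48 h, tested at 1 uM; on this read-out lower numbers stand for a stronger effect and higher numbers for a weaker effect at the one concentration tested. Compound 1 shows 62%, compound 2 shows 69%, and compound 3 shows 79%. Compound 2 arises from compound 1 by a single change, (hydrogen in place of methoxy on an aromatic carbon), and the resulting step, a number 7 percentage points higher from compound 1 to compound 2 (within the scatter), is small. Compound 3 and compound 1 are built on different cores; the difference between the two cores is not broken down here. The numbers for compound 3 and compound 2 lie within the scatter of each other, while those for compound 3 and compound 1 are further apart than that.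

Compound 4 `COc1ccc(-c2cc(/C=C/C(=O)c3cc(OC)c(OC)c(OC)c3)[nH]n2)cc1OC` has not yet been measured in this assay. It arises from compound 3 by the same change, (hydrogen in place of methoxy on an aromatic carbon), at a place described in exactly the same words as before. Within the data shown here, the only guide is a number 7 percentage points higher from compound 1 to compound 2 (within the scatter), a step within the scatter. On that basis compound 4 is expected to show a step of about a number 6 percentage points higher from compound 3 to compound 4 (within the scatter). The estimate for compound 4 is 85%. Its expected range for compound 4 runs from 70% to 98%.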

Compound 4, a percentage reported as activity, at one concentration (the size of the read-out at that concentration, not a potency): 66%
Beside the measured number, compound 4's estimate is 19 percentage points above it, and the stated range ends above it.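

In this assay, putting hydrogen in place of methoxy on an aromatic carbon gives a number 13 percentage points lower from compound 3 to compound 4 (beyond the scatter), which on this read-out means a stronger effect at the one concentration tested. The same change therefore does not carry over as a fixed step from one core to the other: the same change on two cores in this assay, a number 7 percentage points higher (within the scatter) from compound 1 to compound 2 and a number 13 percentage points lower (beyond the scatter) from compound 3 to compound 4, 20 percentage points apart, beyond the scatter of two such steps

These two pairs show only that the size and direction of the step depended on the core in this small set; they offer no rule for any further core, and they do not reveal what lies behind the difference between the two steps.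

Going by these compounds, each number also comes from a single concentration, so it shows only a stronger or weaker effect at that concentration, and how the compounds compare at any other concentration remains open. Also open is how either core would respond if a hydroxy group or a chlorine atom stood in place of that methoxy group, since the compounds shown carry only hydrogen or methoxy there.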